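This account rests on a few compounds, and the source may have more. Where it says the series, first, only, none or still open, it means among the compounds named here.

Measured compounds:
- compound 1 `O=C(COc1ccc2cc(/C=C3/SC(=O)NC3=O)ccc2c1)Nc1ccc(F)cc1`: in an assay on isolated protein for inhibition of histone deacetylase 8 (Homo sapiens), with a stated time of 1 h (on this read-out higher numbers stand for weaker inhibition and lower numbers for stronger inhibition), compound 1 gives 6600 nM
- compound 2 `Cc1cccc2sc(NC(=O)COc3ccc4cc(/C=C5/SC(=O)NC5=O)ccc4c3)nc12`: compound 2 gives 5800 nM
- compound 3 `O=C(COc1ccc2cc(/C=C3/SC(=O)NC3=O)ccc2c1)Nc1ccc(Cl)c(Cl)c1`: compound 3 gives only a limit of the assay, > 50000 nM

Compound 1 stands highest of the two numbers shown, with compound 2 nearest at a 1.1-fold lower number from compound 1 to compound 2 (0.06 log units; within the scatter). Compound 3 sits at the limit (the limit of > 50000 nM in this assay, at which 1 of the 3 values shown sits).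

Compound 4 `O=C(COc1ccc2cc(/C=C3/SC(=O)NC3=O)ccc2c1)Nc1cccc(C(F)(F)F)c1` is not yet measured. It differs from compound 1 in one place: 3-(trifluoromethyl)phenyl in place of 4-fluorophenyl on an amide-type nitrogen. Going by the values given here, two measured steps bear on it, both at the same amide-type nitrogen. The step of a 1.1-fold lower number from compound 1 to compound 2 (0.06 log units; within the scatter) lies within the scatter; the step of an at least 7.5-fold higher number from compound 1 to compound 3 (0.87 log units; beyond the scatter) is a clear loss. A substituted phenyl ring again enters here, so a loss beyond the scatter is expected, though smaller than that of compound 3. The expected step is estimated as a 2.3-fold higher number from compound 1 to compound 4 (0.36 log units; beyond the scatter). Compound 4 is therefore estimated at 15000 nM, with a range of 5000 nM to 50000 nM.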

Compound 4, half-maximal inhibitory concentration: > 50000 nM
Compound 4 gave a limit, no number; the forecaster's own chance of this, stated with the estimate: 25%; middle value at least 3.3-fold (0.52 log units) from the limit.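

In this assay compound 4 gives only a limit, not a number, so a second group at the amide-type nitrogen, 3-(trifluoromethyl)phenyl, ends at the assay limit: the limit of > 50000 nM in this assay, at which 2 of the 4 values shown sit. The change is an at least 7.5-fold higher number from compound 1 to compound 4 (0.87 log units; beyond the scatter), and an at least 8.6-fold higher number from compound 2 to compound 4 (0.93 log units; beyond the scatter), so the loss no longer rests on the 3,4-dichlorophenyl group of compound 3 alone, though compound 1 and compound 2 show that not every group here loses. The step between compound 3 and compound 4 cannot be read, as both values are limits.

Still open, going by these compounds, is whether a phenyl ring carrying a single chlorine, an amine or a carboxylic acid at this nitrogen would give a number.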